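The source may hold more compounds than are shown below. What is called first, only, known or untested is meant among the compounds shown, and "the series" means these compounds.

Compound 1 `COCc1ccc(-c2ccc3nnc(C(N)=O)c(N[C@@H](C)C4CCOCC4)c3c2)cn1`: 140 nM in an assay on HT-29 cells for inhibition of Serine-protein kinase ATM (Homo sapiens), read by fluorescence, with a stated time of 1 h; on this read-out higher numbers stand for weaker inhibition and lower numbers for stronger inhibition.
Compound 2 `C[C@H](Nc1c(C(N)=O)nnc2ccc(-c3ccc(OCCCN4CCCC4)nc3)cc12)C1CCOCC1`: 1.8 nM in this assay.

Within the data shown here, compound 2 holds the lower of the two numbers, and the single measured step, a 78-fold lower number from compound 1 to compound 2 (1.89 log units; beyond the scatter), is large. Compound 3 `C[C@H](Nc1c(C(N)=O)nnc2ccc(-c3ccc(NCCN(C)C)nc3)cc12)C1CCOCC1` differs from compound 2 by (2-(dimethylamino)ethyl)amino in place of 3-(pyrrolidin-1-yl)propoxy on an aromatic carbon. Among the measured compounds shown here, no measured step covers an exchange of one such side chain for another; the step from compound 1 to compound 2 shows only that the group at this position can shift the number greatly. For compound 3 a modest shift in this assay is expected, close to the scatter. Compound 3 is estimated at 4 nM, with a range of 1 nM to 20 nM, a step of a 2.2-fold higher number from compound 2 to compound 3 (0.35 log units; beyond the scatter).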

Compound 3, half-maximal inhibitory concentration: 61 nM
Compound 3: middle estimate off by 15-fold (1.18 log units), on the low side; measured number outside the range, above it.
By their numbers in this assay, from the lowest: compound 2; then compound 3; then compound 1.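

Changing one amine-bearing side chain for another at this position is not a minor exchange: (2-(dimethylamino)ethyl)amino in place of 3-(pyrrolidin-1-yl)propoxy gives a 34-fold higher number from compound 2 to compound 3 (1.53 log units; beyond the scatter). Measured against methoxymethyl, the same (2-(dimethylamino)ethyl)amino gives only a 2.3-fold lower number from compound 1 to compound 3 (0.36 log units; beyond the scatter), so an amine in the side chain does not by itself bring the large gain seen with compound 2. Nothing measured here explains the gap between these two side chains.

The compounds shown leave open which part of the exchange matters, as the linking atom, the chain and the ring all change together. A 3-(dimethylamino)propoxy chain would keep the linking oxygen and chain of compound 2 while removing only its pyrrolidine ring.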